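The source may hold more compounds than are shown below. What is called first, only, known or untested is meant among the compounds shown, and "the series" means these compounds.

In a functional assay on A549 cells (Homo sapiens) for cytotoxicity, read by MTT assay, with a stated time of 72 h (on this read-out higher numbers stand for weaker inhibition and lower numbers for stronger inhibition), compound 1 (`O=C(Nc1ccc(Oc2ccnc3[nH]ccc23)c(F)c1)c1nn(-c2ccccc2)ccc1=O`) gives 56800 nM and compound 2 (`O=C(Nc1ccc(Oc2ccnc3[nH]ccc23)c(F)c1)c1nn(-c2ccc(Cl)c(C(F)(F)F)c2)ccc1=O`) gives 13400 nM as the lower of the two numbers. Compound 3 (`Cn1ccc2c(Oc3ccc(NC(=O)c4nn(-c5ccc(Cl)c(C(F)(F)F)c5)ccc4=O)cc3F)ccnc21`) differs from compound 2 by methyl in place of hydrogen on an aromatic nitrogen in the shared core, with methyl in place of hydrogen on an aromatic nitrogen. For the measured compounds named here, the only measured step is a 4.2-fold lower number from compound 1 to compound 2 (0.63 log units; beyond the scatter) on a different group, so it guides size alone and no measured step tests this change. A small move toward a higher number is expected in this assay, estimated as a 1.5-fold higher number from compound 2 to compound 3 (0.17 log units; within the scatter). Compound 3 is estimated at 20000 nM with an expected range from 7000 nM to 55000 nM in this read-out.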

Compound 3, half-maximal inhibitory concentration: 17700 nM
Compound 3: the middle estimate sits 1.1-fold (0.05 log units) above what was measured; measured number inside the range.
By their numbers in this assay, from the lowest: compounds 2 and 3 (each within the scatter of the next); then compound 1.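

On this aromatic nitrogen of the five-membered aromatic ring, methyl in place of hydrogen gives a 1.3-fold higher number from compound 2 to compound 3 (0.12 log units; within the scatter) in this assay. For the compounds shown here, this is the first read on the shared core rather than the aryl group on the other aromatic nitrogen, and it shows that the hydrogen on this nitrogen can be replaced by methyl without a change beyond the scatter. Nothing at hand explains this result.

From the compounds shown here alone, whether a longer chain or an amine-bearing chain on this nitrogen would be tolerated remains open. Also open, going by these compounds, is whether methyl has the same outcome with plain phenyl, as in compound 1.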